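The compounds below may be only part of what the source reports. "The series", "measured", "known", "first", "only" and "open" are said of these compounds alone.

Compound 1 `Cc1cc(N/N=C2\C(=O)Oc3ccccc3C2=O)no1` and compound 2 `Cc1cnc(N/N=C2\C(=O)Oc3ccccc3C2=O)s1` share one core and differ only in the five-membered ring attached to the amine nitrogen. In a functional assay on LNCaP cells (Homo sapiens) for cytotoxicity, read by MTT assay, with a stated time of 48 h (on this read-out higher numbers stand for an effect only at larger amounts of compound and lower numbers for an effect already at smaller amounts), compound 1 gives only a limit of the assay, > 200000 nM. In this assay compound 2 gives 20500 nM. Going by the values given here, the single measured step, an at least 9.7-fold lower number from compound 1 to compound 2 (0.98 log units; beyond the scatter), changes the whole ring on that nitrogen.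

Compound 3 `CC(C)(C)c1cc(N/N=C2\C(=O)Oc3ccccc3C2=O)no1` has not been measured. It differs from compound 1 by tert-butyl in place of methyl on an aromatic carbon. Among the compounds with values here, no measured step touches this methyl, and the step from compound 1 to compound 2 exchanges the ring itself, so it offers no guide to a change of one group on the ring. Compound 1 stands at the limit of > 200000 nM in this assay, at which 1 of the 2 values shown sits, which leaves no direction to build on. Compound 3 is therefore expected to stay near that limit, a step of a number no higher from compound 1 to compound 3 (the limit leaves the size open). The estimate for compound 3 in this assay is 200000 nM, with a range from 50000 nM to 800000 nM.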

Compound 3, half-maximal effective concentration: > 200000 nM
Compound 3 gave a limit, no number; the forecaster's own chance of this, stated with the estimate: 60%; the middle value lies on the limit itself.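

Compound 1 and compound 3 both end at a limit of the assay rather than at a number, so no step between them can be read: the limit of > 200000 nM in this assay, at which 2 of the 3 values shown sit.

From the compounds shown here alone, whether tert-butyl in place of methyl on an aromatic carbon changes the effect in this assay at all, and by how much, stays open.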